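The source may hold more compounds than are shown below. What is called first, only, known or untested is meant among the compounds shown, and "the series" means these compounds.

Measured so far:
compound 1, `COc1cccc(OC)c1C(=O)Nc1c[nH]nc1C(=O)NC1CCCCCC1` — 42000 nM
compound 2, `COc1ccccc1C(=O)Nc1c[nH]nc1C(=O)N[C@H]1CC[C@H](OC)CC1` — 1500 nM
compound 3, `CO[C@H]1CC[C@H](NC(=O)c2n[nH]cc2NC(=O)c2ccccc2C(F)(F)F)CC1` — 3300 nM

All three were tested in an ADME assay on MRC5 cells (Homo sapiens) for inhibition, with a stated time of 72 h; on this read-out lower numbers stand for an effect already at smaller amounts and higher numbers for an effect only at larger amounts of compound. Compound 1 has the highest number of the three; compound 3 comes nearest to it, and compound 2 lies furthest away. Among the compounds with values here, the only step between compounds that differ in one place, a 2.2-fold higher number from compound 2 to compound 3 (0.34 log units; beyond the scatter), concerns a group on an aromatic carbon and so says nothing about the amide nitrogen. Compound 4, `COc1cccc(OC)c1C(=O)Nc1c[nH]nc1C(=O)NC1CC1`, differs from compound 1 in exactly one place: cyclopropyl in place of cycloheptyl on an amide-type nitrogen. Within the data shown here, no measured step bears on this change, so the size of the move is unknown and the change is expected to give a 1.1-fold higher number from compound 1 to compound 4 (0.03 log units; within the scatter), with wide uncertainty. Compound 4 is therefore estimated at 45000 nM, within a range from 12000 nM to 160000 nM.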

Compound 4, half-maximal effective concentration: > 50000 nM
Compound 4 was reported as a limit; the forecaster's own chance of this, stated with the estimate: 25%; middle value at least 1.1-fold (0.04 log units) from the limit.
By their numbers in this assay, from the lowest: compound 2; then compound 3; then compound 1. At a limit, above all of these: compound 4.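

Within the data shown here, compound 4 gives the first measured step at this position, on an amide-type nitrogen whose other neighbour is the carbonyl carbon: an at least 1.1-fold higher number from compound 1 to compound 4 (0.07 log units; that floor lies within the scatter). For compound 4, the value of > 50000 nM is a limit and not a number, so the full size of this step stays unknown: the limit of > 50000 nM in this assay, at which 1 of the 4 values shown sits. Swapping cycloheptyl for cyclopropyl did not lower the number in this assay, but no rise beyond the scatter is shown either. On these data alone, how a cyclopentyl ring, a longer open chain or a chain carrying an amine would read on this nitrogen remains open.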